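A few compounds are considered here, and "the series" means these few. Any claim that something is new, unique, unknown or untested is made for them only; others in the source may bear on it.

Compound 1 `NC(N)=NC(=O)c1ncc(-c2ccccc2)nc1N`: 35%
Compound 2 `NC(N)=NC(=O)c1ncc(-c2cccc(-c3ccccc3)c2)nc1N`: 72%

In an assay for inhibition of acid-sensing ion channel 3 (Homo sapiens), read by patch clamp, tested at 1 uM (on this read-out higher numbers stand for more inhibition at the one concentration tested (going by the name of the read-out) and lower numbers for less inhibition), compound 1 gives 35%, the lowest of the two numbers; its nearest neighbour is compound 2, and the step of a number 37 percentage points higher from compound 1 to compound 2 (beyond the scatter) lies beyond the scatter. Compound 3 `NC(N)=NC(=O)c1ncc(-c2ccccc2-c2ccccc2)nc1N` differs from compound 1 by phenyl in place of hydrogen on an aromatic carbon. For the measured compounds named here, only the step from compound 1 to compound 2 bears on this change, and it was large, but the phenyl there entered at a different place on the same ring, so the estimated step is set smaller. A rise is expected for compound 3, of a number 20 percentage points higher from compound 1 to compound 3 (beyond the scatter). Compound 3 is estimated at 55%, ranging from 30% to 80%.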

Compound 3, a percentage reported as inhibition, at one concentration (the size of the read-out at that concentration, not a potency): 8%
Compound 3: the middle estimate sits 47 percentage points above what was measured; the measured number lies below the stated range.
By their numbers in this assay, from the lowest: compound 3; then compound 1; then compound 2.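

Phenyl in place of hydrogen gave a number 37 percentage points higher from compound 1 to compound 2 (beyond the scatter) at one place on the ring and a number 27 percentage points lower from compound 1 to compound 3 (beyond the scatter) when ortho to a large group, so the direction of the step depends on where on this ring the phenyl enters. Adding the phenyl therefore does not by itself raise inhibition in these compounds. Nothing available explains why this place differs.

The compounds shown leave open whether a smaller group ortho to a large group, such as methyl or an amine, would also lower the number. They also leave open whether a fluorine atom there would make the number higher, lower or level.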